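This account rests on a few compounds, and the source may have more. Where it says the series, first, only, none or still open, it means among the compounds named here.

In an assay on FRT cells for positive allosteric modulation of Cystic fibrosis transmembrane conductance regulator variant N1303K (Homo sapiens), in the presence of a further agent that is not named here (a higher number here means that more compound is needed for the effect, a lower number that less compound is needed), three compounds have been measured:

compound 1 `COc1ccc2[nH]c3c(c2c1)CCNC31CCN(Cc2ccccc2)CC1`: 12600 nM
compound 2 `COc1ccc2[nH]c3c(c2c1)CCNC31CCN(Cc2cc(Cl)ccc2[N+](=O)[O-])CC1`: 7100 nM
compound 3 `COc1ccc2[nH]c3c(c2c1)CCNC31CCN(Cc2c(F)ccc(Cl)c2F)CC1`: 1500 nM

Compound 3 gives the lowest number of the three, separated from compound 2 by a 4.7-fold lower number from compound 2 to compound 3 (0.68 log units; beyond the scatter) and from compound 1 by an 8.4-fold lower number from compound 1 to compound 3 (0.92 log units; beyond the scatter). Compound 4 `COc1ccc2[nH]c3c(c2c1)CCNC31CCN(Cc2ccc(F)c(Cl)c2F)CC1` differs from compound 3 only in the arrangement of the same atoms: 3-chloro-2,4-difluorophenyl in place of 3-chloro-2,6-difluorophenyl on a saturated chain carbon bound to an amine nitrogen in a ring. Within the data shown here, no measured step moves a halogen around this ring; the steps from compound 1 and compound 2 to compound 3 show only that the substituent pattern on this ring shifts the number modestly. Compound 4 is therefore expected to sit near compound 3, with a step of a 1.5-fold higher number from compound 3 to compound 4 (0.17 log units; within the scatter), giving an estimated 2200 nM with a range from 700 nM to 7000 nM in this assay.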

Compound 4, half-maximal effective concentration: 4500 nM
Estimate against measurement, compound 4: 2.0-fold (0.31 log units) below; the range from low to high includes it.
By their numbers in this assay, from the lowest: compound 3; then compounds 4, 2 and 1 (each within the scatter of the next, the first and the last beyond it).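

With the same atoms rearranged, there is a 3.0-fold higher number from compound 3 to compound 4 (0.48 log units; beyond the scatter) in this assay and this shows that the arrangement of the halogens on the benzyl group matters, not only which halogens it carries. Against phenyl there is still a 2.8-fold lower number from compound 1 to compound 4 (0.45 log units; beyond the scatter) while the comparison with 5-chloro-2-nitrophenyl gives a 1.6-fold lower number from compound 2 to compound 4 (0.20 log units; within the scatter) and so separates nothing. No evidence is available on what lies behind this difference.

Still open, as far as these compounds go, is whether a benzyl group carrying a single chlorine or a single fluorine would do as well as either difluoro pattern. Also open, from the compounds shown here alone, is how a pyridine ring in place of this phenyl ring would behave.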